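Extending the para position of compound 3 from methoxy to phenyl

A few compounds are considered here, and "the series" means these few. Any claim that something is new, unique, unknown or untested is made for them only; others in the source may bear on it.

Compound 1, `CCCCCCCCCCCCn1nnc(C(C(=O)Nc2ncccc2C)c2ccccc2)n1`, gives 85 nM in an assay on liver for inhibition of sterol O-acyltransferase 1 (Rattus norvegicus), using microsomes; on this read-out higher numbers stand for weaker inhibition and lower numbers for stronger inhibition.
Compound 2, `CCCCCCCCCCCCn1nnc(C(C(=O)NC2CC2)c2ccccc2)n1`, gives 244 nM in this assay.
Compound 3, `CCCCCCCCCCCCn1nnc(C(C(=O)Nc2c(OC)cc(OC)cc2OC)c2ccc(OC)cc2)n1`, gives 200 nM in this assay.

Among these three numbers compound 3 stands second highest; its nearest neighbour is compound 2, within the scatter, while its gap to compound 1 lies beyond the scatter. Compound 4, `CCCCCCCCCCCCn1nnc(C(C(=O)Nc2c(OC)cc(OC)cc2OC)c2ccc(-c3ccccc3)cc2)n1`, has not been measured. It differs from compound 3 by phenyl in place of methoxy on an aromatic carbon. Among the measured compounds shown here, the only measured step, a 2.9-fold higher number from compound 1 to compound 2 (0.46 log units; beyond the scatter), concerns the group on the amide-type nitrogen, not the aromatic ring changed here, so no measured step bears on the change from compound 3 to compound 4. With nothing to point in either direction, the expectation for compound 4 is a step of no change at the digits printed from compound 3 to compound 4 (within the scatter), that is, no change beyond the scatter, with a wide range. Compound 4 is therefore estimated at 200 nM in this assay, between 60 nM and 700 nM.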

Compound 4, half-maximal inhibitory concentration: 221 nM
Estimate against measurement, compound 4: 1.1-fold (0.04 log units) below; measured number inside the range.
By their numbers in this assay, from the lowest: compound 1; then compounds 3, 4 and 2 (each within the scatter of the next).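

Replacing methoxy with phenyl gives a 1.1-fold higher number from compound 3 to compound 4 (0.04 log units; within the scatter) in this assay, the first step shown at this position on the aromatic ring, para to a large group. Here a group of 6 heavy atoms with its own aromatic ring and no hydrogen-bond acceptor takes the place of a 2-heavy-atom group with one acceptor, yet the two numbers stay within the scatter of each other. Nothing shown here explains why such different groups read alike.

This single pair cannot show whether other groups at this position would also read alike, such as an amine or a carboxylic acid. It also leaves open whether the same swap would read alike with cyclopropyl or 3-methylpyridin-2-yl on the amide nitrogen.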